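The source may hold more compounds than are shown below. What is called first, only, known or untested is meant among the compounds shown, and "the series" means these compounds.

Measured in a functional assay on NCI-H1975 cells (Homo sapiens) for antiproliferative activity; a lower number here means a stronger inhibitor, a higher number a weaker inhibitor:
- Compound 1 `Cc1c2c(n3c1CCCN(C)[C@@H](C)[C@H](C)Nc1cc-3ccc1C(N)=O)CC(C)(C)CC2=O`: 69 nM
- Compound 2 `CC(=O)N1CCc2c(C)c3c(n2-c2ccc(C(N)=O)c(c2)N[C@@H](C)[C@H](C)C1)CC(C)(C)CC3=O`: 15 nM
- Compound 3 `Cc1c2c(n3c1CCCN(C(=O)CN)[C@@H](C)[C@H](C)Nc1cc-3ccc1C(N)=O)CC(C)(C)CC2=O`: 380 nM

Of these three, compound 2 has the lowest number, at 15 nM, making it the strongest inhibitor so far in this assay. Compound 4 `Cc1c2c(n3c1CCN(C(=O)C(C)(C)N)C[C@@H](C)[C@H](C)Nc1cc-3ccc1C(N)=O)CC(C)(C)CC2=O` has not yet been measured. It departs from compound 2 by 1-amino-1-methylethyl in place of methyl on a carbonyl carbon, so that acetyl becomes (1-amino-1-methylethyl)carbonyl.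

Among the measured compounds shown here, one measured step bears on this change: a 5.5-fold higher number from compound 1 to compound 3 (0.74 log units; beyond the scatter), where (aminomethyl)carbonyl takes the place of methyl on an amine nitrogen in a ring. That step is only a loose guide. For the measured compounds named here, it starts from methyl rather than acetyl, the core of compound 1 is not that of compound 2, and no measured step shows the 1-amino-1-methylethyl group itself. A rise of similar size is therefore expected, though with wide uncertainty.

The expected change is a 4.0-fold higher number from compound 2 to compound 4 (0.60 log units; beyond the scatter). For compound 4 the estimated value is 60 nM, with an expected range of 15 nM to 250 nM.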

Compound 4, half-maximal inhibitory concentration: 21 nM
Estimate against measurement, compound 4: 2.9-fold (0.46 log units) above, and the stated range covers the measured number.
By their numbers in this assay, from the lowest: compounds 2 and 4 (each within the scatter of the next); then compound 1; then compound 3.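

On the carbonyl carbon of the amide-type ring nitrogen, the swap of methyl for 1-amino-1-methylethyl leaves compound 2 and compound 4 indistinguishable in this assay, with a 1.4-fold higher number from compound 2 to compound 4 (0.15 log units; within the scatter), so this position accepts a branched group bearing an amine without a measurable cost. The earlier step, a 5.5-fold higher number from compound 1 to compound 3 (0.74 log units; beyond the scatter), lies beyond the scatter, but it replaces methyl on the ring nitrogen itself and belongs to a different core, so its penalty does not carry over to this acyl change. No measurement shown here accounts for the result.

It remains open whether the two methyl groups of 1-amino-1-methylethyl matter on this core, as the compounds shown include no plain aminomethyl group on it. Whether a carboxylic acid or a longer chain ending in an amine would fare the same at this carbonyl carbon also stays unanswered.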